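A few compounds are considered here, and "the series" means these few. Any claim that something is new, unique, unknown or untested is made for them only; others in the source may bear on it.

In a functional assay on the whole organism with Rattus norvegicus as the target (a higher number here means that more compound is needed for the effect, a lower number that less compound is needed), compound 1 (`CCOCCOC(=O)C(=O)Nc1nc(-c2cc(Br)no2)cs1`) sits at a limit of the assay, > 30 mg/kg, and has no measured number. Compound 2 (`CCOCCOC(=O)C(=O)Nc1nc(-c2cc(Br)no2)c(CC)s1`) gives 9 mg/kg. Among the measured compounds shown here, the only measured step is an at least 3.3-fold lower number from compound 1 to compound 2 (0.52 log units; beyond the scatter), and it comes from ethyl in place of hydrogen on an aromatic carbon. Compound 3 (`CCOCCOC(=O)C(=O)Nc1nc(-c2conc2C)cs1`) differs from compound 1 elsewhere: 3-methyl-1,2-oxazol-4-yl in place of 3-bromo-1,2-oxazol-5-yl on an aromatic carbon. The ethyl step does not concern this group, so its size does not carry over, and no step beyond the scatter is expected in this assay. The expected step is a step that the limit leaves unreadable from compound 1 to compound 3. For compound 3 the estimated value is 35 mg/kg, with an expected range of 12 mg/kg to 100 mg/kg.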

Compound 3, dose for half-maximal effect: > 100 mg/kg
Compound 3 ended at the assay's limit (the forecaster's own chance of this, stated with the estimate: 60%); middle value at least 2.8-fold (0.45 log units) away from the limit.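

Among the compounds shown here, compound 1 and compound 3 both stand at limits of the assay, and no step between them can be read. Still open, as far as these compounds go, is how 3-methyl-1,2-oxazol-4-yl compares with 3-bromo-1,2-oxazol-5-yl once both give measured numbers.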